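Oxolan-3-yl for (pyridin-2-yl)methyl in compound 2

This account rests on a few compounds, and the source may have more. Where it says the series, first, only, none or still open, it means among the compounds named here.

Values so far in a physicochemical assay for lipophilicity, at pH 7.4 (a higher number here means a more lipophilic compound, a lower number a more polar compound), for this series
- compound 1 `Cc1cc(NC(=O)c2c(F)cccc2F)nn1Cc1cc(Cl)ccc1OCc1ccccc1` reads > 3.7 as a limit
- compound 2 `Cc1cc(NC(=O)OCc2ccccn2)nn1Cc1cc(Cl)ccc1OCc1ccccc1` reads 3.1 as a number

Compound 1 gives > 3.7 as a limit of the assay and not as a number. Within the data shown here, compound 2 at 3.1 therefore holds the only true number, and it stands lower than compound 1.

Compound 3 `Cc1cc(NC(=O)O[C@H]2CCOC2)nn1Cc1cc(Cl)ccc1OCc1ccccc1` has not yet been measured. It differs from compound 2 by oxolan-3-yl in place of (pyridin-2-yl)methyl on an oxygen next to a carbonyl group in that oxolan-3-yl sits in place of (pyridin-2-yl)methyl on an oxygen next to a carbonyl group.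

Among the measured compounds shown here, the one measured step of a number at least 0.60 log units lower from compound 1 to compound 2 (beyond the scatter) is beyond the scatter and acts on the same carbonyl group, but it exchanges a different pair of groups. For the measured compounds named here, no step has been measured for this exchange itself. Going by the values given here, with only that guide, no step beyond the scatter is expected in this assay for compound 3. The estimated step runs a number 0.10 log units lower from compound 2 to compound 3 (within the scatter) and stays small. Compound 3 is expected at 3 with an estimated range from 2.6 to 3.4 in this measurement.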

Compound 3, distribution coefficient: 2.7
Compound 3: middle estimate off by 0.30 log units, on the high side, within the range that was stated.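

In this assay, the group on an oxygen next to a carbonyl group now has a measured effect, as oxolan-3-yl in place of (pyridin-2-yl)methyl gives a number 0.40 log units lower from compound 2 to compound 3 (beyond the scatter). This is the only step shown with a number at each end, and it shows that this position still moves the read-out when the carbonyl and its oxygen stay fixed. On a carbonyl carbon, (oxolan-3-yl)oxy in place of 2,6-difluorophenyl gives a number at least 1.00 log units lower from compound 1 to compound 3 (beyond the scatter), and that size remains only a bound because compound 1 stands at a limit of the assay: the limit of > 3.7 in this assay, at which 1 of the 3 values shown sits.

Compound 2 and compound 3 differ in both the ring and the way it is attached to the oxygen, so the contribution of each to the step remains unresolved. On these data alone, it is also open how an amine, a carboxylic acid or a longer chain on the same oxygen would read in this assay, and whether the opposite stereocentre of oxolan-3-yl would read the same.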